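The source may hold more compounds than are shown below. What is called first, only, known or untested is meant among the compounds shown, and "the series" means these compounds.

Working notes on the series.

Compound 1 `C[C@@H](O[C@H]1CN2C(=O)C=C(c3ccncc3)CC2[C@@H]1c1ccc(F)cc1)c1cc(C(F)(F)F)cc(C(F)(F)F)c1` and compound 2 `C[C@@H](O[C@H]1CN2C(=O)C=C(c3ccc[n+]([O-])c3)CC2[C@@H]1c1ccc(F)cc1)c1cc(C(F)(F)F)cc(C(F)(F)F)c1` share one core and differ only in the group on a double-bonded ring carbon. In an assay on CHO cells for displacement of a labelled ligand from Substance-P receptor (Homo sapiens) (on this read-out higher numbers stand for weaker inhibition and lower numbers for stronger inhibition), compound 1 gives 0.14 nM, and in this assay compound 2 gives 0.15 nM. For the measured compounds named here, the only measured step, a 1.1-fold higher number from compound 1 to compound 2 (0.03 log units; within the scatter), is within the scatter, so on these two numbers compound 2 and compound 1 cannot be told apart.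

Compound 3 `C[C@@H](O[C@H]1CN2C(=O)C=C(C3CCOCC3)CC2[C@@H]1c1ccc(F)cc1)c1cc(C(F)(F)F)cc(C(F)(F)F)c1` is the next point. Its change from compound 2 is a group of 6 heavy atoms (5 carbon, 1 oxygen; one six-membered non-aromatic ring with 1 hetero atom) in place of a group of 7 heavy atoms (5 carbon, 1 nitrogen, 1 oxygen; one six-membered aromatic ring with 1 hetero atom), on a double-bonded ring carbon. The measured step bears on it only loosely: it swapped one six-membered aromatic ring with a hetero atom for another and left the number flat, whereas here a six-membered non-aromatic ring enters. Going by the values given here, no step of that kind has been measured, so the expected direction rests on little. A modest drift to a higher number, a 2.7-fold higher number from compound 2 to compound 3 (0.43 log units; beyond the scatter), is expected for compound 3, within or just beyond the scatter. Compound 3 is therefore estimated at 0.4 nM in this assay, in the range 0.1 nM to 1.5 nM.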

Compound 3, half-maximal inhibitory concentration: 0.09 nM
The estimate for compound 3 lay 4.4-fold (0.65 log units) above the measured number; measured number below the stated range.
By their numbers in this assay, from the lowest: compounds 3, 1 and 2 (each within the scatter of the next).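

At this double-bonded ring carbon, oxan-4-yl was compared with two six-membered aromatic rings in this assay, and both steps stay within the scatter (a 1.7-fold lower number from compound 2 to compound 3 (0.22 log units; within the scatter) and a 1.6-fold lower number from compound 1 to compound 3 (0.19 log units; within the scatter)). The earlier compounds shown here covered only six-membered aromatic rings with 1 hetero atom, whereas compound 3 shows that a six-membered non-aromatic ring with 1 hetero atom at this position cannot be told apart from them on these numbers. No measurement among these data accounts for the numbers staying so close.

Still open, as far as these compounds go, is whether a group without a ring at this carbon, such as a short alkyl chain, would stay in the same range. Also open, from the compounds shown here alone, is how a carboxylic acid or a primary amine on the oxan-4-yl ring would read in this assay.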